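The source may hold more compounds than are shown below. What is called first, only, known or untested is meant among the compounds shown, and "the series" means these compounds.

Notes on the series, read in an ADME assay on MDCK cells (Canis lupus familiaris) for cytotoxicity, read by MTT assay, with a stated time of 48 h; a lower number here means that less compound is tolerated, a higher number that more compound is tolerated. Compound 1 `Cc1cccc(NC(=O)CSc2nc(-c3ccccc3)cc(-c3ccccc3)c2C#N)c1` gives > 250000 nM, which is a limit of the assay. Compound 3 `CC[C@H](C)[C@H](NC(=O)CSc1nc(-c2ccccc2)cc(-c2ccc(C)cc2)c1C#N)C(=O)OC` gives > 250000 nM, also a limit. Among the measured compounds shown here, compound 2 `COC(=O)[C@H](CC(C)C)NC(=O)CSc1nc(-c2ccccc2)cc(-c2ccc(C)cc2)c1C#N` gives 215000 nM, the only actual number in the set. The remaining data are bounded by the limit of > 250000 nM in this assay, at which 2 of the 3 values shown sit.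

Compound 4 `COC(=O)[C@H](CCCNC(=N)N)NC(=O)CSc1nc(-c2ccccc2)cc(-c2ccc(C)cc2)c1C#N` has not yet been measured. Its difference from compound 2 is a group of 6 heavy atoms (3 carbon, 3 nitrogen; no ring) in place of a group of 3 heavy atoms (3 carbon; no ring), on a saturated chain carbon, two bonds along the chain from an amide-type nitrogen and a carbonyl carbon. The entering group holds nitrogen, while the group that leaves holds only carbon.

For the measured compounds named here, the one measured step that bears on this change is an at least 1.1-fold higher number from compound 2 to compound 3 (0.06 log units; that floor lies within the scatter). That step swaps one carbon-only group for another, so it guides this larger change only loosely. Going by the values given here, no measured step in the set tests a nitrogen-bearing group at this place. No step beyond the scatter is therefore expected in this assay, with low confidence. The expected change is a 1.2-fold lower number from compound 2 to compound 4 (0.08 log units; within the scatter), an estimate that stays within the scatter. For compound 4 the estimated value is 180000 nM, with an expected range from 60000 nM to 250000 nM.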

Compound 4, half-maximal cytotoxic concentration: > 250000 nM
Compound 4: a limit, no number (the forecaster's own chance of this, stated with the estimate: 30%); at least 1.3-fold (0.14 log units) between middle value and limit.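

In this assay, among the compounds shown here, the place on a saturated chain carbon, two bonds along the chain from an amide-type nitrogen and a carbonyl carbon, now carries a nitrogen-bearing group, which the earlier compounds did not test there. The exchange of isopropyl for this larger group with hydrogen-bond donors gives an at least 1.1-fold higher number from compound 2 to compound 4 (0.06 log units; that floor lies within the scatter) and so shows no sign of a lower number, though that floor lies within the scatter. The step from compound 3 to compound 4 cannot be read, and little of this series can be resolved at the top of the range: the limit of > 250000 nM in this assay, at which 3 of the 4 values shown sit.

From the compounds shown here alone, whether a carboxylic acid or a primary amine at this place would bring the number down to a readable value stays open. A shorter chain ending in the same nitrogen group is equally untested here, and no order among the groups at this place can be drawn.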